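Replacing (3-chloropyridin-2-yl)carbonyl with ethylsulfonyl

This account rests on a few compounds, and the source may have more. Where it says the series, first, only, none or still open, it means among the compounds named here.

Compound 1 `Cc1ccncc1C(=O)N1CC(Oc2cncc(N3C(=O)c4ccc(Cl)cc4C3(C)C)c2)C1`: 5.4 10^-6 cm/s
Compound 2 `CC1(C)c2cc(Cl)ccc2C(=O)N1c1cncc(OC2CN(C(=O)c3ncccc3Cl)C2)c1`: 3.32 10^-6 cm/s

In an ADME assay for permeability, using PAMPA, with a stated time of 18 h (on this read-out higher numbers stand for higher permeability and lower numbers for lower permeability), compound 2 gives 3.32 10^-6 cm/s, which lies within the scatter of compound 1 at 5.4 10^-6 cm/s. Compound 3 `CCS(=O)(=O)N1CC(Oc2cncc(N3C(=O)c4ccc(Cl)cc4C3(C)C)c2)C1` keeps the shared core and differs from compound 2 in one place: ethylsulfonyl in place of (3-chloropyridin-2-yl)carbonyl on an amine nitrogen in a ring. Put simply, it has ethylsulfonyl in place of (3-chloropyridin-2-yl)carbonyl on an amine nitrogen in a ring. Going by the values given here, the only measured step is a 1.6-fold lower number from compound 1 to compound 2 (0.21 log units; within the scatter). That step exchanges one group on a carbonyl carbon for another, whereas the new change removes the carbonyl itself. Among the compounds with values here, no measured compound carries ethylsulfonyl, so the data offer no direct guide. Resting on that one small step, no change beyond the scatter is expected in this assay. The expected step is a 1.3-fold higher number from compound 2 to compound 3 (0.10 log units; within the scatter). The estimate for compound 3 is 4.2 10^-6 cm/s, with an expected range from 1.8 10^-6 cm/s to 10 10^-6 cm/s.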

Compound 3, apparent permeability: 4.17 10^-6 cm/s
Compound 3: the middle estimate sits 1.0-fold (0.00 log units) above what was measured, within the range that was stated.
By their numbers in this assay, from the lowest: compounds 2, 3 and 1 (each within the scatter of the next).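

On the amine nitrogen in a ring, compound 1 and compound 2 differ only in the aromatic group on a carbonyl carbon, whereas ethylsulfonyl replaces both the carbonyl and the ring, with 5 heavy atoms entering where 9 leave compound 2. Even so, this assay gives a 1.3-fold higher number from compound 2 to compound 3 (0.10 log units; within the scatter) and a 1.3-fold lower number from compound 1 to compound 3 (0.11 log units; within the scatter) for this change. So among these three compounds, this position keeps its reading within the scatter with or without a carbonyl or an aromatic ring, and nothing available offers a reason for this result.

The compounds shown leave open how a longer chain on the sulfonyl, or a group carrying an amine or a carboxylic acid on the same nitrogen, would read in this assay at this position. They also leave open whether the ethylsulfonyl exchange would give a similar result on a different core.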